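The source may report more compounds than this note shows. Statements on the series, on what has been measured and on what is new or still open speak of the compounds shown alone.

Three compounds of one series have been examined in a toxicity assay on MDCK cells (Canis lupus familiaris) for cytotoxicity, read by crystal violet staining, with a stated time of 48 h (on this read-out lower numbers stand for higher toxicity in this test and higher numbers for lower toxicity in this test), and none of them has yet yielded a number. Compound 1 `Cc1ccc2cc(CN(Cc3ccc(C(C)C)cc3)Cc3cccc(F)c3)c(=O)[nH]c2c1` gives > 33000 nM, which is a limit of the assay rather than a measured value. Compound 2 `Cc1ccc2cc(CN(Cc3ccc(F)cc3)Cc3ccc(C(C)(C)C)cc3)c(=O)[nH]c2c1` likewise gives > 33000 nM, again a limit. Compound 3 `Cc1ccc2[nH]c(=O)c(CN(Cc3ccccc3)Cc3ccc(C(C)(C)C)cc3)cc2c1` gives > 5000 nM in this assay, also a limit. Where compound 3 stands on the numbers shown is thus not a position at all: every value is a boundary of the test, namely (the limit of > 33000 nM in this assay, at which 2 of the 3 values shown sit), and (the limit of > 5000 nM in this assay, at which 1 of the 3 values shown sits). Among the measured compounds shown here, no step between measured compounds can be drawn from these three results.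

Compound 4 `CSc1ccc(CN(Cc2ccc(C(C)(C)C)cc2)Cc2cc3cc(C)ccc3[nH]c2=O)cc1` has not yet been measured in this assay. It differs from compound 3 in one place: methylsulfanyl in place of hydrogen on an aromatic carbon. The same difference, cut one bond further out, reads benzyl to 4-(methylsulfanyl)benzyl.

For the measured compounds named here, with every value so far a limit, there is no measured step to lean on, and nothing in the data connects the entering group to any shift in this assay. The step that the limit leaves unreadable from compound 3 to compound 4 is expected to be none beyond the scatter. Compound 4 is expected to give 30000 nM in this assay, within a range of 6000 nM to 100000 nM, and most probably to be reported as a limit once more.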

Compound 4, half-maximal cytotoxic concentration: > 5000 nM
Compound 4 was reported as a limit (the forecaster's own chance of this, stated with the estimate: 80%); the middle value does not contradict the limit.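

No new step can be read, as compound 3 and compound 4 both sit at a limit of this assay and neither has yielded a number: the limit of > 5000 nM in this assay, at which 2 of the 4 values shown sit.

The compounds shown leave open whether methylsulfanyl in place of hydrogen on an aromatic carbon shifts the half-maximal cytotoxic concentration at all, and where any of these compounds would reach it.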